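This account rests on a few compounds, and the source may have more. Where it says the series, first, only, none or still open, it means among the compounds named here.

Working notes on the series. Three thiosemicarbazide-linked amides sharing one core have been measured in a functional assay on CNE-2 cells (Homo sapiens) for cytotoxicity, read by MTT assay, with a stated time of 72 h; a lower number here means a stronger inhibitor, a higher number a weaker inhibitor. Compound 1 `Cc1ccc(C(=O)NC(=S)NNc2ncnc3ccccc23)cc1` gives 17200 nM. Compound 2 `O=C(NC(=S)NNc1ncnc2ccccc12)c1cccc(Cl)c1` gives 2920 nM, and compound 3 `O=C(NC(=S)NNc1ncnc2ccccc12)c1ccc(F)cc1` gives 2840 nM. Compound 3 carries the lowest number of the three, but its gap to compound 2, a 1.0-fold lower number from compound 2 to compound 3 (0.01 log units; within the scatter), lies within the scatter, so the two cannot be separated; only compound 1 stands apart, with a 6.1-fold lower number from compound 1 to compound 3 (0.78 log units; beyond the scatter) and a 5.9-fold lower number from compound 1 to compound 2 (0.77 log units; beyond the scatter) both beyond the scatter.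

Compound 4 `O=C(NC(=S)NNc1ncnc2ccccc12)c1ccccc1Cl` is the next member. Its change from compound 3: 2-chlorophenyl in place of 4-fluorophenyl on a carbonyl carbon.

Bearing on this are the two halogen-bearing analogues: the exchange of 3-chlorophenyl for 4-fluorophenyl, a 1.0-fold lower number from compound 2 to compound 3 (0.01 log units; within the scatter), moved nothing beyond the scatter, whereas both departures from 4-methylphenyl were modest gains. Among the measured compounds shown here, no compound so far shows a 2-chlorophenyl, so the new position is untested. In this assay the step from compound 3 to compound 4 is expected to be small, a 1.3-fold higher number from compound 3 to compound 4 (0.13 log units; within the scatter), leaning toward a somewhat higher number. Compound 4 is therefore estimated at 3800 nM, within 1300 nM to 11000 nM.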

Compound 4, half-maximal inhibitory concentration: 6090 nM
Compound 4: middle estimate off by 1.6-fold (0.20 log units), on the low side; the measured number falls inside the stated range.
By their numbers in this assay, from the lowest: compounds 3 and 2 (each within the scatter of the next); then compound 4; then compound 1.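

In this assay, the group on the carbonyl carbon now separates two chlorine- or fluorine-bearing phenyls, which compounds 2 and 3 did not do: 2-chlorophenyl in place of 3-chlorophenyl gives a 2.1-fold higher number from compound 2 to compound 4 (0.32 log units; beyond the scatter), and 2-chlorophenyl in place of 4-fluorophenyl gives a 2.1-fold higher number from compound 3 to compound 4 (0.33 log units; beyond the scatter). The 2-chlorophenyl group still keeps part of the gain over 4-methylphenyl, with a 2.8-fold lower number from compound 1 to compound 4 (0.45 log units; beyond the scatter), so compound 4 sits between compound 1 and the pair of compounds 2 and 3. No measurement is available that accounts for these steps.

The compounds shown leave open whether the higher number of compound 4 follows the place of the chlorine on the phenyl or the chlorine itself. Going by these compounds, how this position responds to a phenyl bearing an amine or a carboxylic acid also remains open.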